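This account rests on a few compounds, and the source may have more. Where it says the series, first, only, none or still open, it means among the compounds named here.

Two members of the series carry measurements in an ADME assay on Huh-7 cells (Homo sapiens) for cytotoxicity; on this read-out higher numbers stand for lower toxicity in this test and lower numbers for higher toxicity in this test. Compound 1 `O=C(NC(=S)N1CCc2c(OCCCCCOc3ccc(Cl)cc3)cccc21)c1ccc(F)cc1` gives 31100 nM. Compound 2 `O=C(NC(=S)N1CCc2c(OCCCCCOc3ccc(Cl)cc3)cccc21)c1ccsc1` reaches only the assay limit of > 50000 nM, not a number. The step of an at least 1.6-fold higher number from compound 1 to compound 2 (0.20 log units; that floor lies within the scatter) rests on that limit (the limit of > 50000 nM in this assay, at which 1 of the 2 values shown sits), so compound 2 stands at the top of the numbers shown without an exact figure. Compound 3 `S=C(NC(=S)N1CCc2c(OCCCCCOc3ccc(Cl)cc3)cccc21)Oc1ccccc1` differs from compound 2 by a group of 9 heavy atoms (7 carbon, 1 oxygen, 1 sulfur; one six-membered aromatic ring of carbon only) in place of a group of 7 heavy atoms (5 carbon, 1 oxygen, 1 sulfur; one five-membered aromatic ring with 1 hetero atom), on an amide-type nitrogen, an exchange of one aromatic ring for another on the same nitrogen. For the measured compounds named here, no measured step covers this exchange; the single step from compound 1 to compound 2 concerns a different ring swap and did not exceed the scatter. For compound 3 no movement beyond the scatter is expected, so the step that the limit leaves unreadable from compound 2 to compound 3 is estimated as small. The expected value for compound 3 is 60000 nM, with a range from 25000 nM to 150000 nM, and a further limit rather than a number is considered likely.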

Compound 3, half-maximal cytotoxic concentration: > 50000 nM
Compound 3 ended at the assay's limit; the forecaster's own chance of this, stated with the estimate: 60%; the middle value is on the limit's open side.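

In this assay compound 3 gives > 50000 nM, which is a limit of the assay and not a number. Its group on the amide-type nitrogen gives an at least 1.6-fold higher number from compound 1 to compound 3 (0.20 log units; that floor lies within the scatter), so this second exchange at the same place, like the thiophen-3-yl one, shows no step beyond the scatter. The step between the two compounds at the limit cannot be read, and the new group can only be said to join compound 2 there: the limit of > 50000 nM in this assay, at which 2 of the 3 values shown sit.

As far as these compounds go, how far compound 2 and compound 3 lie past the limit stays open, so the two groups cannot be ranked against each other. Also open, from the compounds shown here alone, is whether an amine or a carboxylic acid in this place would give an exact figure in this assay.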